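This account rests on a few compounds, and the source may have more. Where it says the series, first, only, none or still open, it means among the compounds named here.

Measured in an ADME assay on WI-38 cells (Homo sapiens) for cytotoxicity, read by MTT assay, with a stated time of 72 h; on this read-out higher numbers stand for weaker inhibition and lower numbers for stronger inhibition:
compound 1 `O=C(CCc1cccc2c1B(O)OC2)Nc1nccs1`: a limit of the assay only, > 100000 nM
compound 2 `O=C(CCc1cccc2c1B(O)OC2)Nc1ccc(Br)cc1`: 42000 nM
compound 3 `CC(C)c1cccc(NC(=O)CCc2cccc3c2B(O)OC3)c1`: 22000 nM

Compound 3 and compound 2 lie within the scatter of each other, so neither can be set above the other on these numbers. Compound 1 sits at the limit of > 100000 nM in this assay, at which 1 of the 3 values shown sits. For the measured compounds named here, the one measured step, an at least 2.3-fold lower number from compound 1 to compound 2 (0.37 log units; beyond the scatter), exchanges the group on the amide-type nitrogen and so does not speak to a change on the aromatic ring. Compound 4 `O=C(CCc1cccc2c1B(O)OC2)Nc1cccc(-c2cccc(C(F)(F)F)c2)c1` differs from compound 3 in 3-(trifluoromethyl)phenyl in place of isopropyl on an aromatic carbon. Going by the values given here, no measured step bears on this change, so the expected step of a 1.1-fold lower number from compound 3 to compound 4 (0.04 log units; within the scatter) is nothing beyond the scatter. Compound 4 is estimated at 20000 nM, with a range from 7000 nM to 60000 nM.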

Compound 4, half-maximal inhibitory concentration: 23000 nM
For compound 4 the middle estimate is 1.2-fold (0.06 log units) below the measured one, and the stated range covers the measured number.
By their numbers in this assay, from the lowest: compounds 3, 4 and 2 (each within the scatter of the next). At a limit, above all of these: compound 1.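

With a 1.0-fold higher number from compound 3 to compound 4 (0.02 log units; within the scatter) in this assay, exchanging isopropyl for 3-(trifluoromethyl)phenyl on an aromatic carbon, meta to a large group, leaves the number within the scatter. For the compounds shown here, this position therefore takes the added six-membered aromatic ring of carbon only with no readable shift, which the earlier compounds, with no measured change here, could not show. Nothing measured here accounts for this result.

Going by these compounds, an amine or a carboxylic acid at this position remains open. So does whether a smaller group, such as a methyl, would also leave the number within the scatter.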